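Amine substituent series, cytotoxicity working notes

The source may report more compounds than this note shows. Statements on the series, on what has been measured and on what is new or still open speak of the compounds shown alone.

Measured so far:
compound 1, `O=C(Nc1ccc(NCC2CCCC2)cc1Cl)c1cc(Cl)ccc1O`, gives 21500 nM in an ADME assay on A549 cells (Homo sapiens) for cytotoxicity, read by resazurin assay, with a stated time of 48 h; a higher number here means that more compound is tolerated, a lower number that less compound is tolerated
compound 2, `CN(C)c1ccc(NC(=O)c2cc(Cl)ccc2O)c(Cl)c1`, gives 85100 nM in this assay
compound 3, `COc1ccc(CNc2ccc(NC(=O)c3cc(Cl)ccc3O)c(Cl)c2)cc1`, gives 80700 nM in this assay

Compound 3 holds the second highest of the three numbers in this assay; against compound 2 it lies within the scatter, and only compound 1 stands apart, lower and beyond the scatter. The shared core is kept throughout; the three differ only in the substituent on the amine nitrogen.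

Compound 4, `CC(CCO)Nc1ccc(NC(=O)c2cc(Cl)ccc2O)c(Cl)c1`, is not yet measured. The change from compound 3 is 3-hydroxy-1-methylpropyl in place of 4-methoxybenzyl on a nitrogen on an aromatic ring.

Among the measured compounds shown here, two steps bear on it, both starting from compound 1: a 4.0-fold higher number from compound 1 to compound 2 (0.60 log units; beyond the scatter) and a 3.8-fold higher number from compound 1 to compound 3 (0.57 log units; beyond the scatter). Both replace the cyclopentylmethyl substituent on the amine nitrogen and both raise the number by a comparable modest amount, and the two products, compound 2 and compound 3, lie within the scatter of each other. For the measured compounds named here, no measured step shows a hydroxy-bearing chain at this position, so the direction for compound 4 is not fixed by the data. Compound 4 is expected near the level of compound 2 and compound 3 rather than compound 1, and the step of a 1.2-fold lower number from compound 3 to compound 4 (0.09 log units; within the scatter) is estimated to stay within the scatter. Compound 4 is estimated at 65000 nM, with a range from 28000 nM to 150000 nM.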

Compound 4, half-maximal cytotoxic concentration: 200000 nM
Compound 4: middle estimate off by 3.1-fold (0.49 log units), on the low side, outside the stated range (above it).
By their numbers in this assay, from the lowest: compound 1; then compounds 3 and 2 (each within the scatter of the next); then compound 4.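

In this assay the substituent on the amine nitrogen has more range than compounds 1 to 3 suggested, since the level shared by compound 2 and compound 3 is not a ceiling: 3-hydroxy-1-methylpropyl gives a 2.5-fold higher number from compound 3 to compound 4 (0.39 log units; beyond the scatter) and, as the amino group in place of dimethylamino, a 2.4-fold higher number from compound 2 to compound 4 (0.37 log units; beyond the scatter) in this series. Set against cyclopentylmethyl, the same open-chain group gives the largest step among these compounds, a 9.3-fold higher number from compound 1 to compound 4 (0.97 log units; beyond the scatter) and thus extends the span at this one position, with the core unchanged. No measurement at hand accounts for this rise.

Still open, on these data alone, is which part of the entering group carries the step: the hydroxy group, the branching methyl or the chain as a whole. A straight 3-hydroxypropyl, a 3-methoxy-1-methylpropyl, a longer hydroxyalkyl chain or a chain ending in a carboxylic acid or an amine on this nitrogen would separate these parts, and the compounds shown do not tell whether any of them would follow compound 4.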